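Propyl to phenyl on the hydroxyacyl chain of compound 1

This account rests on a few compounds, and the source may have more. Where it says the series, first, only, none or still open, it means among the compounds named here.

Compound 1 `CCCC[C@@H](O)C(=O)N1N=CC[C@H]1C(=O)NCc1cc(Cl)ccc1-n1cnnn1`: 610 nM
Compound 2 `O=C(NCc1cc(Cl)ccc1-n1cnnn1)[C@@H]1C[C@@H]2C[C@@H]2N1C(=O)[C@H](O)c1cccc(Cl)c1`: 1000 nM
Compound 3 `O=C(NCc1cc(Cl)ccc1-n1cnnn1)[C@@H]1C[C@@H]2C[C@@H]2N1C(=O)[C@H](O)c1ccccc1`: 620 nM

In a functional assay on a cell-free system (plasma, Homo sapiens), with a stated time of 3 min (on this read-out lower numbers stand for stronger inhibition and higher numbers for weaker inhibition), compound 1 gives the lowest of the three numbers, yet its distance to compound 3 and to compound 2 stays within the scatter, so no order among the three can be claimed. Within the data shown here, the only step between measured compounds is a 1.6-fold lower number from compound 2 to compound 3 (0.21 log units; within the scatter), a change on an aromatic ring rather than on the chain. Compound 4 `O=C(NCc1cc(Cl)ccc1-n1cnnn1)[C@@H]1CC=NN1C(=O)[C@H](O)Cc1ccccc1` differs from compound 1 as phenyl in place of propyl on a saturated chain carbon, two bonds along the chain from a carbonyl carbon and an oxygen on a saturated carbon. Among the measured compounds shown here, no measured step touches this chain position, so the expectation rests on compound 1 alone. Compound 4 is therefore expected to sit near compound 1, with a step of a 1.0-fold lower number from compound 1 to compound 4 (0.01 log units; within the scatter). The estimate for compound 4 is 600 nM, in a range from 300 nM to 1200 nM.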

Compound 4, half-maximal inhibitory concentration: 1400 nM
Compound 4: middle estimate off by 2.3-fold (0.37 log units), on the low side, outside the stated range (above it).
By their numbers in this assay, from the lowest: compounds 1, 3, 2 and 4 (each within the scatter of the next, the first and the last beyond it).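

In this assay, phenyl in place of propyl at this chain position gives a 2.3-fold higher number from compound 1 to compound 4 (0.36 log units; beyond the scatter), a modest step and the only one among these compounds that lies beyond the scatter. Among these compounds, it shows that this position, which no earlier step touched, responds to the change, and that here the phenyl group goes with weaker inhibition than the propyl group. No evidence at hand bears on the reason for this step. What the compounds shown leave open is whether the aromatic ring or the larger group goes with this step. On these data alone, how a cyclohexyl group, a longer chain or an amine would read at this position also stays open.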